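The source may report more compounds than this note shows. Statements on the series, on what has been measured and on what is new or still open speak of the compounds shown alone.

For the compounds measured so far (an ADME assay on NHDF cells (Homo sapiens) for cytotoxicity, read by MTT assay, with a stated time of 72 h; on this read-out higher numbers stand for weaker inhibition and lower numbers for stronger inhibition):
Compound 1 `COc1cccc(/C=C2\CCC/C(=C\c3ccc(Cl)cc3)C2=O)c1OC` gives 18600 nM
Compound 2 `COc1cccc(/C=C2\CCC/C(=C\c3cccc(OC)c3OC)C2=O)c1` gives 16400 nM
Compound 3 `COc1cccc(/C=C2\CCC/C(=C\c3cc(Cl)cc(Cl)c3)C2=O)c1OC` gives 21600 nM

Compound 3 stands level with the other two, as the steps to it show (a 1.2-fold higher number from compound 1 to compound 3 (0.06 log units; within the scatter)) (a 1.3-fold higher number from compound 2 to compound 3 (0.12 log units; within the scatter)). Compound 4 (`COc1cccc(/C=C2\CCC/C(=C\c3ccc(O)c(O)c3)C2=O)c1OC`) differs from compound 3 in one place (3,4-dihydroxyphenyl in place of 3,5-dichlorophenyl on a double-bonded chain carbon bound to a double-bonded ring carbon). The measured steps that bear on this are the swaps at that same place, namely the two above and one more (a 1.1-fold lower number from compound 1 to compound 2 (0.05 log units; within the scatter)). All three remain within the scatter. Within the data shown here, no measured compound carries a 3,4-dihydroxyphenyl, so these steps are only a loose guide. No step beyond the scatter is therefore expected in (this assay), in either direction. The expected step is small (a 1.5-fold lower number from compound 3 to compound 4 (0.19 log units; within the scatter)). Compound 4 is estimated at (14000 nM), with an expected range from (5000 nM) to (32000 nM).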

Compound 4, half-maximal inhibitory concentration: 17900 nM
Compound 4: middle estimate off by 1.3-fold (0.11 log units), on the low side; the range from low to high includes it.
By their numbers in this assay, from the lowest: compounds 2, 4, 1 and 3 (each within the scatter of the next).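

In this assay, the 3,4-dihydroxyphenyl group on a double-bonded chain carbon bound to a double-bonded ring carbon stands level with all three earlier groups at this place (a 1.2-fold lower number from compound 3 to compound 4 (0.08 log units; within the scatter)) (a 1.1-fold higher number from compound 2 to compound 4 (0.04 log units; within the scatter)) (a 1.0-fold lower number from compound 1 to compound 4 (0.02 log units; within the scatter)). Thus, hydroxyl-bearing 3,4-dihydroxyphenyl, with hydrogen-bond donors and acceptors that 3,5-dichlorophenyl lacks, produces no step beyond the scatter. Nothing available explains this level result. The compounds shown leave open whether an amine or a carboxylic acid on this phenyl ring would stay level as well.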